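Ring-nitrogen amines and a chloro on the phenyl sulfone

The source may hold more compounds than are shown below. What is called first, only, known or untested is meant among the compounds shown, and "the series" means these compounds.

Measured compounds:
compound 1 `O=S(=O)(c1ccccc1)c1cn(C2CCNC2)c2ccccc12` — 70%
compound 2 `O=S(=O)(c1ccccc1)c1cn(C2CCNCC2)c2ccccc12` — "not determined" (no result reported)
compound 3 `CCN1CCCC(n2cc(S(=O)(=O)c3ccccc3)c3ccccc32)C1` — 52%

In a functional assay on HeLa cells for agonist activity at 5-hydroxytryptamine receptor 6 (Homo sapiens), read by cAMP accumulation and immunoassay, with a stated time of 10 min (on this read-out higher numbers stand for larger maximal responses and lower numbers for smaller maximal responses), compound 1 gives 70%, the higher of the two numbers obtained; compound 2 has no reported result in this assay. Among the measured compounds shown here, the one step that can be read runs a number 18 percentage points lower from compound 1 to compound 3 (beyond the scatter), a modest lowering when 1-ethylpiperidin-3-yl replaces pyrrolidin-3-yl on the aromatic nitrogen.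

Compound 4 `O=S(=O)(c1cccc(Cl)c1)c1cn(C2CCNC2)c2ccccc12` is not yet measured. Relative to compound 1 it differs by chloro in place of hydrogen on an aromatic carbon, a change on the phenyl sulfone side rather than on the amine side of the shared core. For the measured compounds named here, none of the measured steps touches this position, so the step from compound 1 to compound 3 does not bear on it directly; it shows only that a change elsewhere in the molecule shifted the maximal response by a modest amount. Going by the values given here, with no precedent for the chloro, compound 4 is expected to stay near compound 1, and the step of a number 5 percentage points lower from compound 1 to compound 4 (within the scatter) is estimated to fall within or just beyond the scatter in either direction. The value for compound 4 in this assay is therefore estimated at 65%, with a range of 45% to 85%.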

Compound 4, largest response reached (Emax), in percent of the reference or control that the assay uses: 48%
Compound 4: the middle estimate sits 17 percentage points above what was measured; measured number inside the range.
By their numbers in this assay, from the lowest: compounds 4 and 3 (each within the scatter of the next); then compound 1.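

In this assay, phenyl to 3-chlorophenyl gives a number 22 percentage points lower from compound 1 to compound 4 (beyond the scatter) and so shows that the phenyl sulfone side of the shared core is not silent: a single chlorine on an aromatic carbon, meta to a large group, is enough to move the maximal response. Among the compounds shown here, earlier, the only readable step lay on the amine side, a number 18 percentage points lower from compound 1 to compound 3 (beyond the scatter); each side now has one step, and in both the number falls below that of compound 1. Nothing in the data accounts for the lowering at this position.

As far as these compounds go, it remains open whether the lowering belongs to chloro itself or to this place on the ring, and whether another group here, such as fluoro, methoxy or an amine, would hold the response nearer to compound 1. Also open, from the compounds shown here alone, is how chloro would behave with 1-ethylpiperidin-3-yl on the aromatic nitrogen, and steps to compound 2 cannot be read, as it has no reported result.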